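Phenyl in Place of 4-Methoxyphenoxy: Expected Solubility

A few compounds are considered here, and "the series" means these few. Any claim that something is new, unique, unknown or untested is made for them only; others in the source may bear on it.

Among the measured compounds shown here, compound 1 `COc1ccc(Oc2ccc3c(NCCCNCc4cccc(OC)c4O)ccnc3c2)cc1` gives 14500 nM in a physicochemical assay for solubility, with a stated time of 18 h, at pH 7.4 (a higher number here means a more soluble compound, a lower number a less soluble compound), the higher of the two numbers measured so far. Compound 2 `COc1ccc(F)cc1CNCCCNc1ccnc2cc(CC(C)C)ccc12` gives 4200 nM in this assay, a gap beyond the scatter. Compound 3 `COc1cccc(CNCCCNc2ccnc3cc(-c4ccccc4)ccc23)c1O` has not yet been measured. It differs from compound 1 in one place: phenyl in place of 4-methoxyphenoxy on an aromatic carbon. For the measured compounds named here, no step between measured compounds matches this change, so the expectation rests on compound 1 alone. The step of a 2.4-fold lower number from compound 1 to compound 3 (0.38 log units; beyond the scatter) is expected to be a moderate drop in this assay, somewhat beyond the scatter. Compound 3 is therefore expected to give 6000 nM in this assay, within a range from 2000 nM to 18000 nM.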

Compound 3, solubility: 32000 nM
Compound 3: the middle estimate sits 5.3-fold (0.73 log units) below what was measured; the whole stated range lies below it.
By their numbers in this assay, from the lowest: compound 2; then compound 1; then compound 3.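

Phenyl in place of 4-methoxyphenoxy on this aromatic carbon gives a 2.2-fold higher number from compound 1 to compound 3 (0.34 log units; beyond the scatter) in this assay, the only single-place step shown at this position. The number rises even though the change keeps one six-membered aromatic ring of carbon only and takes the hydrogen-bond acceptors of the group from 2 to 0. No measurement at hand accounts for this rise. Going by these compounds, this one step removes the methoxy group and the ether oxygen together, and which of them matters stays open. On these data alone, how phenoxy or an amine on this carbon would read in this assay is also open.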